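A few compounds are considered here, and "the series" means these few. Any claim that something is new, unique, unknown or untested is made for them only; others in the source may bear on it.

The measured compounds, all built on the shared core of compound 1:

- compound 1, `CCN1CCN(c2cc(C)c3cc(NC(=O)c4ccccc4C)ccc3n2)CC1`
- compound 2, `CCc1ccc(C(=O)Nc2ccc3nc(N4CCN(CC)CC4)cc(C)c3c2)cc1`
- compound 3, `CCN1CCN(c2cc(C)c3cc(NC(=O)c4ccccc4Cl)ccc3n2)CC1`

They differ only in the group on the carbonyl carbon. In a functional assay on SK-BR-3 cells (Homo sapiens) for antiproliferative activity, read by MTT assay, with a stated time of 72 h (on this read-out higher numbers stand for weaker inhibition and lower numbers for stronger inhibition), compound 1 gives 29200 nM. Compound 2 gives 9850 nM, and the change of 4-ethylphenyl in place of 2-methylphenyl brings a 3.0-fold lower number from compound 1 to compound 2 (0.47 log units; beyond the scatter). Among the measured compounds shown here, for compound 3 the assay reports only a limit, > 50000 nM, so no number is known for it; it is the one value sitting at the limit of > 50000 nM in this assay, at which 1 of the 3 values shown sits. Compound 3 therefore stands at the weak end of the three: the steps into it were an at least 1.7-fold higher number from compound 1 to compound 3 (0.23 log units; that floor lies within the scatter) and an at least 5.0-fold higher number from compound 2 to compound 3 (0.70 log units; beyond the scatter).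

Compound 4, `CCN1CCN(c2cc(C)c3cc(NC(=O)c4ccccc4)ccc3n2)CC1`, is compound 3 with hydrogen in place of chloro on an aromatic carbon. The closest comparison is between compound 1 and compound 3, where chloro in place of methyl gave a step whose floor lies within the scatter, so removing the chloro altogether is expected to return compound 4 roughly to the region of compound 1, with some chance that only a limit is again reported. The step from compound 3 to compound 4 is thus expected to be an at least 2.0-fold lower number from compound 3 to compound 4 (0.30 log units; that floor lies within the scatter). For compound 4 the estimate in this assay is 25000 nM, within a range of 8000 nM to 80000 nM.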

Compound 4, half-maximal inhibitory concentration: 18400 nM
For compound 4 the middle estimate is 1.4-fold (0.13 log units) above the measured one; the measured number falls inside the stated range.
By their numbers in this assay, from the lowest: compounds 2, 4 and 1 (each within the scatter of the next, the first and the last beyond it). At a limit, above all of these: compound 3.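

this assay shows that on this aromatic carbon, ortho to a large group, the chloro matters: the step of hydrogen in place of chloro is an at least 2.7-fold lower number from compound 3 to compound 4 (0.43 log units; beyond the scatter), so the plain benzoyl compound returns a real number. The other groups on the ring are not separated from hydrogen: hydrogen in place of methyl gives a 1.6-fold lower number from compound 1 to compound 4 (0.20 log units; within the scatter), and hydrogen in place of ethyl gives a 1.9-fold higher number from compound 2 to compound 4 (0.27 log units; within the scatter), so the gap between compound 1 and compound 2 now divides into two smaller steps, neither of which can be read as a change on its own. The true size of the chloro step stays unknown because compound 3 has only a limit and not a number: the limit of > 50000 nM in this assay, at which 1 of the 4 values shown sits.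

From the compounds shown here alone, it remains open whether fluoro, a smaller halogen, or an amine on the same carbon would behave like the chloro of compound 3 or like the hydrogen of compound 4. Also open, going by these compounds, is whether a longer chain such as butyl, in the place of the ethyl of compound 2, would move the number clearly away from that of compound 4.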